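Amine substituent swap at the benzylic nitrogen of compound 1

The compounds below may be only part of what the source reports. "The series", "measured", "known", "first", "only" and "open" are said of these compounds alone.

Measured so far:
compound 1 `CCC[C@@H](CCO)Nc1nc(N)nc(C)c1Cc1ccc(CNCC(N)=O)cc1OC` — > 10000 nM
compound 2 `CCC[C@@H](CCO)Nc1nc(N)nc(C)c1Cc1ccc(CNC)cc1OC` — 6460 nM
compound 3 `CCC[C@@H](CO)Nc1nc(N)nc(C)c1Cc1ccc(CNC)cc1OC` — 2140 nM

In an assay on HEK293 cells for agonist activity at Toll-like receptor 8 (Homo sapiens) (on this read-out lower numbers stand for an effect already at smaller amounts and higher numbers for an effect only at larger amounts of compound), compound 1 gives only (the limit of > 10000 nM in this assay, at which 1 of the 3 values shown sits), a limit of the assay rather than a number. Compound 2, in which hydrogen replaces the carbamoyl group, reaches 6460 nM, and the change reads as an at least 1.5-fold lower number from compound 1 to compound 2 (0.18 log units; that floor lies within the scatter). Compound 3 shortens the hydroxyalkyl chain and gives 2140 nM, a step of a 3.0-fold lower number from compound 2 to compound 3 (0.48 log units; beyond the scatter); this part of the molecule is unchanged in compound 4, so that step does not bear on the present question.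

Compound 4 `CCC[C@@H](CCO)Nc1nc(N)nc(C)c1Cc1ccc(CNC2CN(C)C2)cc1OC` carries the change (1-methylazetidin-3-yl in place of carbamoylmethyl on an amine nitrogen). No measured step covers this replacement directly; the only related comparison is the removal of the carbamoyl group from compound 1 to compound 2, which lowered the number at least to the extent shown, and compound 1 itself stands at the limit. The expectation is therefore a number below the limit of compound 1, in the region of compound 2, with wide uncertainty. Compound 4 is expected at 4000 nM, between 1000 nM and 15000 nM. This estimate corresponds to an at least 2.5-fold lower number from compound 1 to compound 4 (0.39 log units; beyond the scatter), expected rather than measured.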

Compound 4, half-maximal effective concentration: > 10000 nM
Compound 4: a limit, no number; the forecaster's own chance of this, stated with the estimate: 25%; middle value at least 2.5-fold (0.39 log units) away from the limit.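

In this assay compound 4 gives > 10000 nM, which is a limit of the assay and not a number. Putting 1-methylazetidin-3-yl in place of methyl on the amine nitrogen gives an at least 1.5-fold higher number from compound 2 to compound 4 (0.18 log units; that floor lies within the scatter), so this change is not resolved from the scatter, and the step between the two limit compounds, compound 1 and compound 4, cannot be read. At this nitrogen, with the longer hydroxyalkyl chain, methyl in compound 2 is now the only substituent shown that gives a number, while carbamoylmethyl and 1-methylazetidin-3-yl both end at the limit: the limit of > 10000 nM in this assay, at which 2 of the 4 values shown sit.

Still open, going by these compounds, is how an ethyl group, or a primary amine with hydrogen on this nitrogen, would read in this assay. Also open, on these data alone, is whether 1-methylazetidin-3-yl would give a number on the hydroxyalkyl chain of compound 3.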